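Swapping isopropyl for cyclohexyl on a quinone amidine

This account rests on a few compounds, and the source may have more. Where it says the series, first, only, none or still open, it means among the compounds named here.

Three compounds sharing one core have been measured in a functional assay on DU-145 cells (Homo sapiens) for cytotoxicity, read by MTT assay, with a stated time of 48 h; a higher number here means a weaker inhibitor, a lower number a stronger inhibitor:
compound 1, `COc1cc(N/C(CCNC2=CC(=O)c3ccccc3C2=O)=N\S(=O)(=O)c2ccc(C)cc2)cc(OC)c1OC`, gives 9330 nM
compound 2, `Cc1ccc(S(=O)(=O)/N=C(/CCNC2=CC(=O)c3ccccc3C2=O)Nc2cc(F)c(F)c(F)c2)cc1`, gives 12600 nM
compound 3, `Cc1ccc(S(=O)(=O)/N=C(/CCNC2=CC(=O)c3ccccc3C2=O)NC(C)C)cc1`, gives 28500 nM

Compound 3 stands highest of the three, which in this assay means the weakest inhibitor. Its nearest neighbour is compound 2, reached by a 2.3-fold higher number from compound 2 to compound 3 (0.35 log units; beyond the scatter), and the larger gap is a 3.1-fold higher number from compound 1 to compound 3 (0.48 log units; beyond the scatter). The two aryl-substituted compounds sit close together, as a 1.4-fold higher number from compound 1 to compound 2 (0.13 log units; within the scatter) shows.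

Compound 4, `Cc1ccc(S(=O)(=O)/N=C(/CCNC2=CC(=O)c3ccccc3C2=O)NC2CCCCC2)cc1`, differs from compound 3 in one place: cyclohexyl in place of isopropyl on an amine nitrogen. Within the data shown here, no measured step swaps one alkyl group for another; the steps that bear on it are those where an aryl group replaces isopropyl, and both lowered the number by a modest amount. Cyclohexyl is a ring of similar size to those aryl groups but shares none of their other features, so the guidance is indirect. A small move toward a lower number, or none beyond the scatter, is the expectation for compound 4, expressed as a 1.4-fold lower number from compound 3 to compound 4 (0.15 log units; within the scatter). The estimate for compound 4 in this assay is 20000 nM, with a plausible range from 9000 nM to 45000 nM.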

Compound 4, half-maximal inhibitory concentration: 16600 nM
Compound 4: the middle estimate sits 1.2-fold (0.08 log units) above what was measured, and the stated range covers the measured number.
By their numbers in this assay, from the lowest: compounds 1, 2, 4 and 3 (each within the scatter of the next, the first and the last beyond it).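

In this assay, among these compounds, the swap of isopropyl for cyclohexyl on the amine nitrogen gives a 1.7-fold lower number from compound 3 to compound 4 (0.23 log units; within the scatter) and is the first alkyl-for-alkyl comparison at this position, but it cannot be told apart from no change. Cyclohexyl also stays level with both aryl groups, since replacing 3,4,5-trifluorophenyl gives a 1.3-fold higher number from compound 2 to compound 4 (0.12 log units; within the scatter) and replacing 3,4,5-trimethoxyphenyl gives a 1.8-fold higher number from compound 1 to compound 4 (0.25 log units; within the scatter), while isopropyl was separated from each of those aryl groups by more than the scatter. A ring of carbon only with no aromatic character thus fills the gap between isopropyl and the aryl groups without being distinguishable from either side, and nothing available offers a reason for these numbers.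

From the compounds shown here alone, whether a smaller ring such as cyclopropyl, an unsubstituted phenyl, or a longer chain ending in an amine or a carboxylic acid would move the number beyond the scatter remains open. The rest of the shared core is the same in all four compounds, so it is also unknown whether these small differences at the amine nitrogen would hold if another part of the molecule changed.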